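A Chloro-for-Methyl Swap Repeated on a Second Core

The compounds below may be only part of what the source reports. "The series", "measured", "known", "first", "only" and "open" are said of these compounds alone.

Compound 1 `CCn1c(=O)/c(=C2\Sc3ccc(OC)cc3N2C)s/c1=C\c1ccncc1Nc1ccccc1C` and compound 2 `CCn1c(=O)/c(=C2\Sc3ccc(OC)cc3N2C)s/c1=C\c1ccncc1Nc1ccccc1Cl` share one core and differ only at the outer ring: chloro in place of methyl on an aromatic carbon. In a functional assay on MCF7 cells (Homo sapiens) for inhibition (a higher number here means a weaker inhibitor, a lower number a stronger inhibitor), compound 1 gives 420 nM, and compound 2 gives 710 nM, so this change gave a 1.7-fold higher number from compound 1 to compound 2 (0.23 log units; within the scatter). Compound 3 `CCn1c(=O)/c(=C2\Sc3cc(F)ccc3N2C)s/c1=C\c1ccncc1Nc1ccccc1C` carries a second core; how its core differs from that of compound 1 is not broken down here. In this assay compound 3 gives 1300 nM, the highest of the three numbers, though its gap to compound 2 lies within the scatter. Compound 4 `CCn1c(=O)/c(=C2\Sc3cc(F)ccc3N2C)s/c1=C\c1ccncc1Nc1ccccc1Cl` repeats the earlier change on this second core: chloro in place of methyl on an aromatic carbon. The place matches the first pair word for word, so this is the same change, made for the second time among these compounds. Because a 1.7-fold higher number from compound 1 to compound 2 (0.23 log units; within the scatter) was seen, the step is expected to be of similar size, a 1.7-fold higher number from compound 3 to compound 4 (0.23 log units; within the scatter). Compound 4 is therefore estimated at 2200 nM. Its likely range is expected to run from 1100 nM to 4500 nM, kept wide since this rests on a single earlier pair.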

Compound 4, half-maximal inhibitory concentration: 1300 nM
Beside the measured number, compound 4's estimate is 1.7-fold (0.23 log units) above it, within the range that was stated.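

In this assay, putting chloro in place of methyl on the second core gave no change at the digits printed from compound 3 to compound 4 (within the scatter). Set beside the first pair, the two steps cannot be told apart, so the change behaves alike on both cores within what repeated measurements can resolve: the same change on two cores in this assay, a 1.7-fold higher number (0.23 log units; within the scatter) from compound 1 to compound 2 and no change at the digits printed (within the scatter) from compound 3 to compound 4, 1.7-fold (0.23 log units) apart, within the scatter of two such steps

Among the compounds shown here, this shows only that the swap gives no step beyond the scatter on either of these two cores; it does not show that chloro and methyl truly differ on one core and not on the other, nor that the same result would hold on a third core.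

As far as these compounds go, whether a different group at this place on the outer ring, such as trifluoromethyl, an amine or a carboxylic acid, would give a step beyond the scatter stays open. Also open, from the compounds shown here alone, is whether the swap from 2-methylphenyl to 2-chlorophenyl would stay this small on other cores or in a different kind of test.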